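Chloro to methoxy swap repeated on a second core

This account rests on a few compounds, and the source may have more. Where it says the series, first, only, none or still open, it means among the compounds named here.

Compound 2 `CC1CCN(C2CCN(S(=O)(=O)c3cccc(-c4ccc(Cl)cc4)c3)CC2)CC1` gives 15 nM in a functional assay on DLD-1 cells (Homo sapiens) for antiproliferative activity, read by CellTiter-Glo, with a stated time of 72 h; a lower number here means a stronger inhibitor, a higher number a weaker inhibitor. Compound 1 `COc1ccc(-c2cccc(S(=O)(=O)N3CCC(N4CCC(C)CC4)CC3)c2)cc1` carries one change relative to compound 2, (methoxy in place of chloro on an aromatic carbon); in this assay compound 1 gives 23 nM, a step of a 1.5-fold higher number from compound 2 to compound 1 (0.19 log units; within the scatter). Compound 3 `CC1CCN(C2CCN(S(=O)(=O)c3ccccc3-c3ccc(Cl)cc3)CC2)CC1` has the same atoms as compound 2, joined differently; the difference between the two cores is not broken down here. In this assay compound 3 gives 202 nM, the highest number of the three measured. Compound 4 `COc1ccc(-c2ccccc2S(=O)(=O)N2CCC(N3CCC(C)CC3)CC2)cc1` applies the same change to the core of compound 3: methoxy in place of chloro on an aromatic carbon. Because the earlier step of a 1.5-fold higher number from compound 2 to compound 1 (0.19 log units; within the scatter) stayed within the scatter, for compound 4 a step of a 1.4-fold higher number from compound 3 to compound 4 (0.14 log units; within the scatter) is expected. The estimate for compound 4 is 280 nM, between 120 nM and 700 nM.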

Compound 4, half-maximal inhibitory concentration: 1000 nM
The estimate for compound 4 lay 3.6-fold (0.55 log units) below the measured number, and the stated range ends below it.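

On the core of compound 3, going from 4-chlorophenyl to 4-methoxyphenyl gives a 5.0-fold higher number from compound 3 to compound 4 (0.69 log units; beyond the scatter) in this assay. The size of this step does not carry over unchanged between the two cores: the same change on two cores in this assay, a 1.5-fold higher number (0.19 log units; within the scatter) from compound 2 to compound 1 and a 5.0-fold higher number (0.69 log units; beyond the scatter) from compound 3 to compound 4, 3.2-fold (0.51 log units) apart, beyond the scatter of two such steps

Among these compounds, the direction of the printed values is shared, but only the step on the core of compound 3 lies beyond the scatter; two pairs show that the step size depends on the core here, not why it does, and they set no rule for the wider series.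

Only chloro and methoxy are compared at this place. As far as these compounds go, whether a nitrile or a dimethylamino group would also give steps that differ between the two cores remains open.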